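Hydroxymethyl added to the ether side chain: compound 3

A few compounds are considered here, and "the series" means these few. Any claim that something is new, unique, unknown or untested is made for them only; others in the source may bear on it.

Compound 1 `CC(C)(C)c1cc(-c2cc(=O)c3ccc(OCCO)cc3o2)cc(C(C)(C)C)c1O` holds the highest of the two numbers seen so far: in a functional assay for inhibition (on this read-out lower numbers stand for stronger inhibition and higher numbers for weaker inhibition), compound 1 gives 3000 nM, whereas compound 2 `CN(C)CCCOc1ccc2c(=O)cc(-c3cc(C(C)(C)C)c(O)c(C(C)(C)C)c3)oc2c1` gives 700 nM; the step is a 4.3-fold lower number from compound 1 to compound 2 (0.63 log units; beyond the scatter). Compound 3 `CC(C)(C)c1cc(-c2cc(=O)c3ccc(OCC(O)CO)cc3o2)cc(C(C)(C)C)c1O` differs from compound 1 by hydroxymethyl in place of hydrogen on a saturated chain carbon bound to an oxygen on a saturated carbon and a saturated chain carbon. Among the measured compounds shown here, the single measured step from compound 1 to compound 2 alters the same chain, yet with a different group, so it bears only loosely on this change; no closer precedent exists. The step from compound 1 to compound 3 is therefore expected to remain within the scatter, a 1.2-fold lower number from compound 1 to compound 3 (0.08 log units; within the scatter). Compound 3 is estimated at 2500 nM, range 1000 nM to 6000 nM.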

Compound 3, half-maximal inhibitory concentration: 100 nM
For compound 3 the middle estimate is 25-fold (1.40 log units) above the measured one; measured number below the stated range.
By their numbers in this assay, from the lowest: compound 3; then compound 2; then compound 1.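

Hydroxymethyl on this saturated chain carbon, turning 2-hydroxyethoxy into 2,3-dihydroxypropoxy, gives a 30-fold lower number from compound 1 to compound 3 (1.48 log units; beyond the scatter) and shows that this chain responds strongly to a small addition. The 2,3-dihydroxypropoxy chain also goes beyond the dimethylamino chain, with a 7.0-fold lower number from compound 2 to compound 3 (0.85 log units; beyond the scatter) on that comparison, so an amine on the chain is not needed for the lowest number among these compounds. Nothing available accounts for the size of these steps.

Still open, as far as these compounds go, is whether a methoxy group in place of the added hydroxy would keep the low number. A carboxylic acid or a longer chain carrying further hydroxy groups also remains untested in the compounds shown here.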